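Side chain change from compound 3 to compound 4

This account rests on a few compounds, and the source may have more. Where it says the series, first, only, none or still open, it means among the compounds named here.

In a functional assay on HCT-116 cells (Homo sapiens) for cytotoxicity, read by MTT assay, with a stated time of 72 h (a lower number here means a stronger inhibitor, a higher number a weaker inhibitor), compound 1 `COc1ncc(-c2ccc3nc(NC(=O)N(C)C)nn3c2)cc1NS(=O)(=O)c1ccc(F)cc1` gives 760 nM and compound 2 `COc1ncc(-c2ccc3nc(NC(=O)NC4CC4)nn3c2)cc1NS(=O)(=O)c1ccc(F)cc1` gives 90 nM while compound 3 `COc1ncc(-c2ccc3nc(NC(=O)NCC(=O)N4CCCC4)nn3c2)cc1NS(=O)(=O)c1ccc(F)cc1` gives 140 nM in the same read-out. Compound 3 thus stands with compound 2 and apart from compound 1. Beyond the scatter lie a 5.4-fold lower number from compound 1 to compound 3 (0.73 log units; beyond the scatter) and an 8.4-fold lower number from compound 1 to compound 2 (0.93 log units; beyond the scatter) and both replace dimethylamino on a carbonyl carbon, a change not made here.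

Compound 4 `COc1ncc(-c2ccc3nc(NC(=O)NCCN(C)C)nn3c2)cc1NS(=O)(=O)c1ccc(F)cc1` carries (dimethylamino)methyl in place of (pyrrolidin-1-yl)carbonyl on a saturated chain carbon bound to an amide-type nitrogen so that ((pyrrolidin-1-yl)carbonyl)methyl becomes 2-(dimethylamino)ethyl. The nearest guide is a 1.6-fold higher number from compound 2 to compound 3 (0.19 log units; within the scatter) which stays within the scatter and swaps the substituent on the same amide-type nitrogen. Among the measured compounds shown here, no measured compound carries 2-(dimethylamino)ethyl, and the range is kept wide.

In this assay the expected change is a 1.1-fold higher number from compound 3 to compound 4 (0.03 log units; within the scatter) and no step beyond the scatter is expected. Compound 4 is estimated at 150 nM with an expected range of 50 nM to 450 nM for now.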

Compound 4, half-maximal inhibitory concentration: 220 nM
For compound 4 the middle estimate is 1.5-fold (0.17 log units) below the measured one; measured number inside the range.
By their numbers in this assay, from the lowest: compounds 2, 3 and 4 (each within the scatter of the next, the first and the last beyond it); then compound 1.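

In this assay, the open-chain 2-(dimethylamino)ethyl on the amide-type nitrogen, which has no ring and no side-chain carbonyl, shows a 1.6-fold higher number from compound 3 to compound 4 (0.20 log units; within the scatter), so ((pyrrolidin-1-yl)carbonyl)methyl can be exchanged for it without a step beyond the scatter. Measured against cyclopropyl, however, the same group gives a 2.4-fold higher number from compound 2 to compound 4 (0.39 log units; beyond the scatter), a separation that compound 3 did not show, while the comparison with the dimethylamino end of the series still reads a 3.5-fold lower number from compound 1 to compound 4 (0.54 log units; beyond the scatter) and keeps compound 4 on the side of compound 2. No evidence on the cause of these steps is available.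

Still open, from the compounds shown here alone, is how a longer chain carrying the dimethylamino group, or a morpholine ring in its place, would read in this assay. A carboxylic acid on the chain and a cyclobutyl group in place of cyclopropyl also remain untested in the compounds shown here.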